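Nitro for nitrile on the amide carbonyl

The source may hold more compounds than are shown below. What is called first, only, known or untested is meant among the compounds shown, and "the series" means these compounds.

Compound 1 `O=C(O)c1ccc(C(=O)Nc2cc(-c3ccccc3)nn2-c2ccccc2)cc1` is recorded in an assay on HEK293 cells for displacement of a labelled ligand from metabotropic glutamate receptor 5 (Rattus norvegicus) (on this read-out lower numbers stand for stronger inhibition and higher numbers for weaker inhibition), only as a limit. In this assay compound 1 returns > 10000 nM, a limit of the assay rather than a number. Compound 2 `N#Cc1cccc(C(=O)Nc2cn(-c3ccccc3)nc2-c2ccccc2)c1` likewise stands at a limit. In this assay compound 2 gives > 10000 nM, again a limit and not a measured value. Among the compounds with values here, both entries therefore sit at the limit of > 10000 nM in this assay, at which 2 of the 2 values shown sit, so no step between measured compounds can be drawn and no ranking is possible. Compound 3 `O=C(Nc1cn(-c2ccccc2)nc1-c1ccccc1)c1ccc([N+](=O)[O-])cc1` differs from compound 2 in one place: 4-nitrophenyl in place of 3-cyanophenyl on a carbonyl carbon. With compound 2 at the limit, nothing in the present numbers points in either direction, and no shift beyond the usual scatter is expected. The estimated step is a step that the limit leaves unreadable from compound 2 to compound 3. Compound 3 is accordingly expected near 20000 nM, within 5000 nM to 100000 nM, and most probably reported once more as a limit.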

Compound 3, inhibition constant: > 10000 nM
Compound 3: only a limit was reported; the forecaster's own chance of this, stated with the estimate: 85%; the middle value lies beyond the limit too.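

In this assay compound 3 gives > 10000 nM, a limit and not a number. Within the data shown here, compound 2 also stands at a limit, and no step between compound 2 and compound 3 can be read. The compounds shown leave open which change, if any, would give a measurable value in this assay.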